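The compounds below may be only part of what the source reports. "The series", "measured", "known", "first", "only" and "open" are said of these compounds alone.

Compound 1 `COc1cc(C(C)=O)ccc1OCCCN1CCC(C(c2cccc(F)c2)c2cccc(F)c2)CC1`: 3.16 nM
Compound 2 `COc1cc(C(C)=O)ccc1OCCCN1CCC(C(c2ccc(C)cc2)c2ccc(C)cc2)CC1`: 15.9 nM
Compound 3 `COc1cc(C(=O)O)ccc1OCCCN1CCC(C(c2ccc(F)cc2)c2ccc(F)cc2)CC1`: 79.4 nM

All three were tested in a functional assay (aorta) with Oryctolagus cuniculus as the target; on this read-out lower numbers stand for tighter binding and higher numbers for weaker binding. Compound 3 gives the highest number of the three in this assay; compound 2 sits below it by a margin beyond the scatter, and compound 1 further below, also beyond the scatter. Compound 4 `Fc1ccc(C(c2ccc(F)cc2)C2CCN(CCCSc3ccccc3)CC2)cc1` is not yet measured. Relative to compound 3 the change is phenylsulfanyl in place of 4-carboxy-2-methoxyphenoxy on a saturated chain carbon, three bonds along the chain from an amine nitrogen in a ring. Going by the values given here, no measured pair differs in exactly this way, so the effect can only be anticipated. Because the highest number of the set belongs to compound 3 with 79.4 nM, while compounds 1 and 2, which lack the carboxy group, give lower numbers, compound 4 is expected to move toward them. The estimated step of a 7.9-fold lower number from compound 3 to compound 4 (0.90 log units; beyond the scatter) is toward a lower number, beyond the scatter. Compound 4 is estimated at 10 nM, with a range of 2 nM to 50 nM.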

Compound 4, dissociation constant: 3.16 nM
The estimate for compound 4 lay 3.2-fold (0.50 log units) above the measured number; the measured number falls inside the stated range.
By their numbers in this assay, from the lowest: compounds 1 and 4 (each within the scatter of the next); then compound 2; then compound 3.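

In this assay, phenylsulfanyl in place of 4-carboxy-2-methoxyphenoxy on a saturated chain carbon, three bonds along the chain from an amine nitrogen in a ring, gives a 25-fold lower number from compound 3 to compound 4 (1.40 log units; beyond the scatter). Going by these compounds alone, this is the first single-place comparison in the set, and it shows that this position accepts the smaller group with no hydrogen-bond donor. Nothing at hand explains the step. Because the whole group changes at once, the contributions of the carboxy group, methoxy group and sulfur remain unseparated. Also open, on these data alone, is how an unsubstituted phenoxy group or a longer chain would read here.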